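This account rests on a few compounds, and the source may have more. Where it says the series, first, only, none or still open, it means among the compounds named here.

Working notes on the series. Compound 3 `CC(C)[C@H](NC(=O)COc1cccc2ccccc12)C(=O)N[C@@H](CC(=O)O)C(=O)COc1cccc(C(F)(F)F)c1` has no number in a functional assay on Jurkat cells (Homo sapiens); a higher number here means a weaker inhibitor, a lower number a stronger inhibitor; it sits at a limit of the assay, > 100000 nM. The two measured analogues in this assay do give numbers: compound 1 `CC(C)[C@H](NC(=O)COc1cccc2ccccc12)C(=O)N[C@@H](CC(=O)O)C(=O)COC(=O)c1c(Cl)cccc1Cl` gives 10600 nM, and compound 2 `CC(C)[C@H](NC(=O)COc1cccc2ccccc12)C(=O)N[C@@H](CC(=O)O)C(=O)COc1ccccc1` gives 14000 nM. The step of a 1.3-fold higher number from compound 1 to compound 2 (0.12 log units; within the scatter) shows the two within the scatter of each other. By contrast, an at least 9.4-fold higher number from compound 1 to compound 3 (0.97 log units; beyond the scatter) and an at least 7.1-fold higher number from compound 2 to compound 3 (0.85 log units; beyond the scatter) both run beyond the scatter, the latter being the direct exchange of trifluoromethyl in place of hydrogen on an aromatic carbon; both end at the limit of > 100000 nM in this assay, at which 1 of the 3 values shown sits.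

Compound 4 `CC(C)[C@H](NC(=O)COc1cccc2ccccc12)C(=O)N[C@@H](CC(=O)O)C(=O)COc1ccc(F)cc1F` is the next candidate. The change is 2,4-difluorophenyl in place of 3-(trifluoromethyl)phenyl on an oxygen on a saturated carbon. The step of an at least 7.1-fold higher number from compound 2 to compound 3 (0.85 log units; beyond the scatter) bears on it most closely, since compound 4 drops the trifluoromethyl that set compound 3 apart from compound 2. Compound 2, with unsubstituted phenyl, gives 14000 nM. Among the measured compounds shown here, no measured step covers fluorine on the aromatic ring, so the expected step for compound 4 is worded loosely: a return of part of the distance, an at least 3.3-fold lower number from compound 3 to compound 4 (0.52 log units; beyond the scatter), is expected rather than a further rise. For compound 4 the estimate in this assay is 30000 nM, with a range from 8000 nM to 120000 nM.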

Compound 4, half-maximal inhibitory concentration: 33200 nM
Compound 4: the middle estimate sits 1.1-fold (0.04 log units) below what was measured; measured number inside the range.
By their numbers in this assay, from the lowest: compounds 1 and 2 (each within the scatter of the next); then compound 4. At a limit, above all of these: compound 3.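

Substitution on the phenyl ring at this position does not by itself carry the number to the limit in this assay: the exchange of 3-(trifluoromethyl)phenyl for 2,4-difluorophenyl gives an at least 3.0-fold lower number from compound 3 to compound 4 (0.47 log units; beyond the scatter). Even so, 2,4-difluorophenyl does not match unsubstituted phenyl, with a 2.4-fold higher number from compound 2 to compound 4 (0.38 log units; beyond the scatter), so substitution on this ring can cost a modest step without any trifluoromethyl, and the comparison with the (2,6-dichlorophenyl)carbonyl ester gives a step of similar size, a 3.1-fold higher number from compound 1 to compound 4 (0.50 log units; beyond the scatter). The first of these steps gives only a bound and not a measured size, since compound 3 stands at a limit of the assay: the limit of > 100000 nM in this assay, at which 1 of the 4 values shown sits.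

The compounds shown leave open whether the rise follows the number of substituents, their place on the ring or the kind of group, and how a single fluorine, a methoxy group or an amine on the phenyl ring would fall in this order. They also leave open whether the same order holds once the shared core changes, for instance with an amide in place of its carboxylic acid.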